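This account rests on a few compounds, and the source may have more. Where it says the series, first, only, none or still open, it means among the compounds named here.

Compound 1 `CC(C)C[C@H](N)c1cc(C(F)(F)F)ccc1N1CCN(C(=O)COc2ccc(Cl)cc2)CC1` gives 2900 nM in an assay on HEK293 cells for displacement of a labelled ligand from Melanocortin receptor 4 (Homo sapiens); on this read-out lower numbers stand for stronger inhibition and higher numbers for weaker inhibition. Compound 2 `CC(C)C[C@H](N)c1cc(C(F)(F)F)ccc1N1CCN(C(=O)COc2cccc(Cl)c2Cl)CC1` gives 2500 nM in this assay, and compound 3 `Cc1ccc(OCC(=O)N2CCN(c3ccc(C(F)(F)F)cc3[C@@H](N)CC(C)C)CC2)c(C)c1` gives 4000 nM. The three numbers sit close together: a 1.2-fold lower number from compound 1 to compound 2 (0.06 log units; within the scatter), a 1.4-fold higher number from compound 1 to compound 3 (0.14 log units; within the scatter) and a 1.6-fold higher number from compound 2 to compound 3 (0.20 log units; within the scatter), so compound 3 is not separated from compounds 1 or 2 beyond the scatter.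

Compound 4 `CCOc1cccc(CC(C)C(=O)N2CCN(c3ccc(C(F)(F)F)cc3[C@@H](N)CC(C)C)CC2)c1` differs from compound 3 in this way: 1-(3-ethoxybenzyl)ethyl in place of (2,4-dimethylphenoxy)methyl on a carbonyl carbon. For the measured compounds named here, none of the measured steps touches this part of the molecule; they only swap substituents on the aryl group on the oxygen, and each stayed within the scatter. Going by the values given here, there is thus no step that bears directly on it. The expected step is a 1.3-fold lower number from compound 3 to compound 4 (0.12 log units; within the scatter), with wide uncertainty. Compound 4 is estimated at 3000 nM in this assay, in the range 700 nM to 13000 nM.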

Compound 4, inhibition constant: 2200 nM
Compound 4: the middle estimate sits 1.4-fold (0.13 log units) above what was measured, within the range that was stated.
By their numbers in this assay, from the lowest: compounds 4, 2, 1 and 3 (each within the scatter of the next).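

Changing the group on the carbonyl carbon, rather than only the aryl substituents, still gives no separation in this assay: a 1.8-fold lower number from compound 3 to compound 4 (0.26 log units; within the scatter), a 1.1-fold lower number from compound 2 to compound 4 (0.06 log units; within the scatter) and a 1.3-fold lower number from compound 1 to compound 4 (0.12 log units; within the scatter). Among these four compounds, then, 1-(3-ethoxybenzyl)ethyl stands in for each phenoxymethyl group without leaving the scatter. Nothing available here gives a reason for this. On these data alone, whether a change at this place can move the number beyond the scatter remains open. So does the outcome of an amine or a carboxylic acid in place of the ethoxy group, or of a longer chain on the carbonyl carbon.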